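Triazole Chain Extension in a Diaryl Urea Series

This account rests on a few compounds, and the source may have more. Where it says the series, first, only, none or still open, it means among the compounds named here.

Compound 1 `Cn1cnnc1-c1cc(Oc2ccc(NC(=O)Nc3cccc(C(F)(F)F)c3)cc2F)ccn1`: 3020 nM
Compound 2 `CN(C)CCn1cnnc1-c1cc(Oc2ccc(NC(=O)Nc3ccc(F)c(Cl)c3)cc2F)ccn1`: 720 nM
Compound 3 `CN(C)CCn1cnnc1-c1cc(Oc2ccc(NC(=O)Nc3ccc(Cl)cc3Cl)cc2F)ccn1`: 1890 nM

In a functional assay on HT-29 cells (Homo sapiens) for antiproliferative activity, read by MTT assay, with a stated time of 72 h (on this read-out lower numbers stand for stronger inhibition and higher numbers for weaker inhibition), compound 1 gives the highest of the three numbers; compound 3 lies within the scatter of it, while compound 2 sits beyond the scatter below it. Within the data shown here, the one clean step, a 2.6-fold higher number from compound 2 to compound 3 (0.42 log units; beyond the scatter), concerns the aryl group and not the triazole chain. Compound 4 `CN(C)CCCn1cnnc1-c1cc(Oc2ccc(NC(=O)Nc3cccc(C(F)(F)F)c3)cc2F)ccn1` differs from compound 1 by 2-(dimethylamino)ethyl in place of hydrogen on a saturated chain carbon bound to an aromatic nitrogen. Among the measured compounds shown here, no measured pair isolates this change: compounds 2 and 3 carry a related chain but also other aryl groups, so their lower values only hint at a direction. The author therefore expects a modest lowering, a 2.5-fold lower number from compound 1 to compound 4 (0.40 log units; beyond the scatter), and estimates for compound 4 a value of 1200 nM, between 400 nM and 3600 nM.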

Compound 4, half-maximal inhibitory concentration: 980 nM
Beside the measured number, compound 4's estimate is 1.2-fold (0.09 log units) above it; the range from low to high includes it.
By their numbers in this assay, from the lowest: compounds 2, 4, 3 and 1 (each within the scatter of the next, the first and the last beyond it).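

In this assay the change from methyl to 3-(dimethylamino)propyl gives a 3.1-fold lower number from compound 1 to compound 4 (0.49 log units; beyond the scatter) with the rest of compound 1 unchanged. Among these compounds, this is the first direct reading of the chain at this position, which compound 2 and compound 3 could only hint at, since they also carry other aryl groups. Nothing available explains the step.

As far as these compounds go, whether a longer chain, or a morpholine in place of the dimethylamino group, would shift the number further remains open. So does whether the same step holds with the aryl groups of compound 2 and compound 3.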